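Benzimidazole for phenyl on a diketopiperazine-type scaffold

The compounds below may be only part of what the source reports. "The series", "measured", "known", "first", "only" and "open" are said of these compounds alone.

Measured compounds:
compound 1 `O=c1[nH]/c(=C\c2cccc(Oc3ccc(F)cc3)c2)c(=O)[nH]/c1=C\c1cccnc1`, in a functional assay on NCI-H460 cells (Homo sapiens) for cytotoxicity, read by MTT assay, with a stated time of 72 h (on this read-out higher numbers stand for weaker inhibition and lower numbers for stronger inhibition), compound 1 gives > 1000 nM, a limit rather than a number
compound 2 `O=c1[nH]/c(=C\c2cccc(Oc3ccc(F)cc3)c2)c(=O)[nH]/c1=C\c1ccccc1`, in this assay compound 2 gives 389 nM

Among the compounds with values here, compound 2 stands as the only compound with a definite number in this assay; the value of compound 1 is a limit. Within the data shown here, the one step on record is an at least 2.5-fold lower number from compound 1 to compound 2 (0.41 log units; beyond the scatter). That evidence is thin, since one side rests on (the limit of > 1000 nM in this assay, at which 1 of the 2 values shown sits).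

Compound 3 is `O=c1[nH]/c(=C\c2nc3ccccc3[nH]2)c(=O)[nH]/c1=C\c1cccc(Oc2ccc(F)cc2)c1`. The change from compound 2 is 1H-benzimidazol-2-yl in place of phenyl on a double-bonded chain carbon bound to an aromatic carbon. The only step that bears on it is the reverse move, a heteroaryl in place of phenyl at the same position, which earlier gave the number shown by an at least 2.5-fold lower number from compound 1 to compound 2 (0.41 log units; beyond the scatter) when it went the other way. By analogy, a heteroaromatic group entering here is expected to raise the number, though the entering group differs in kind and size from pyridin-3-yl, so the expectation is loose. Compound 3 is therefore expected to give 800 nM, within 200 nM to 4000 nM, an expected step of a 2.1-fold higher number from compound 2 to compound 3 (0.31 log units; beyond the scatter).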

Compound 3, half-maximal inhibitory concentration: > 1000 nM
Compound 3 gave a limit, no number; the forecaster's own chance of this, stated with the estimate: 40%; at least 1.2-fold (0.09 log units) between middle value and limit.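

In this assay, 1H-benzimidazol-2-yl in place of phenyl on a double-bonded chain carbon bound to an aromatic carbon gives an at least 2.5-fold higher number from compound 2 to compound 3 (0.41 log units; beyond the scatter), so a second heteroaromatic group, different in kind from pyridin-3-yl, also compares poorly with phenyl at this position. Among the three compounds shown, compound 2, which carries phenyl, is the only one with a definite number, and neither heteroaromatic group has so far given a number at this position. The two heteroaromatic groups cannot be ranked against each other, and the step between compound 1 and compound 3 cannot be read: the limit of > 1000 nM in this assay, at which 2 of the 3 values shown sit.

The compounds shown do not separate the part played by the ring nitrogen atoms from that of the added ring in 1H-benzimidazol-2-yl, and they give no number for either heteroaromatic compound. They also leave open whether a group such as naphthalen-2-yl, indol-2-yl or cyclohexyl, or a phenyl carrying a methoxy group or a fluorine, would match or improve on the number of compound 2.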